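Aryl Swap on a Shared Core Before Measurement

The source may report more compounds than this note shows. Statements on the series, on what has been measured and on what is new or still open speak of the compounds shown alone.

Compound 1 `N#CC1=C(N)Oc2c(N)cc3nc4ccccc4nc3c2C12C(=O)N(Cc1cnnn1-c1cccc(Br)c1)c1ccccc12` — > 50000 nM
Compound 2 `CCOc1ccccc1-n1nncc1CN1C(=O)C2(C(C#N)=C(N)Oc3c(N)cc4nc5ccccc5nc4c32)c2ccccc21` — > 50000 nM
Compound 3 `Cc1ccc(-n2nncc2CN2C(=O)C3(C(C#N)=C(N)Oc4c(N)cc5nc6ccccc6nc5c43)c3ccccc32)cc1C` — > 50000 nM

Compound 1, compound 2 and compound 3 share one core and differ only in the aryl group carried on an aromatic nitrogen. In a functional assay on MCF7 cells (Homo sapiens) for antiproliferative activity, read by MTT assay, with a stated time of 48 h (a higher number here means a weaker inhibitor, a lower number a stronger inhibitor), compound 1 gives > 50000 nM, which is a limit of the assay and not a number. Compound 2 likewise gives > 50000 nM, again a limit. Compound 3 gives > 50000 nM, also a limit. The three steps between them cannot be read because the limit of > 50000 nM in this assay, at which 3 of the 3 values shown sit, leaves no direction to read: a step that the two limits leave unreadable from compound 1 to compound 2, a step that the two limits leave unreadable from compound 1 to compound 3 and a step that the two limits leave unreadable from compound 2 to compound 3 all stay hidden. Compound 3 therefore stands at the limit, alongside the other two, with no ranking among them possible.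

Compound 4 `N#CC1=C(N)Oc2c(N)cc3nc4ccccc4nc3c2C12C(=O)N(Cc1cnnn1-c1ccc(Cl)cc1Cl)c1ccccc12` has not yet been measured. It differs from compound 3 by 2,4-dichlorophenyl in place of 3,4-dimethylphenyl on an aromatic nitrogen. Every measured step bears on this change in the loose sense that each swaps one aryl group for another at the same place, yet none of them has a readable size. Compound 4 is expected to sit near the limit, with the step of a number no higher from compound 3 to compound 4 (the limit leaves the size open) being the estimate rather than a finding. The estimate for compound 4 in this assay is 50000 nM, spanning 20000 nM to 100000 nM.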

Compound 4, half-maximal inhibitory concentration: > 50000 nM
Compound 4 ended at the assay's limit; the forecaster's own chance of this, stated with the estimate: 85%; the middle value lies on the limit itself.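

Within the data shown here, no step from compound 1, compound 2 or compound 3 to compound 4 can be read in this assay and no ranking among the four is possible: the limit of > 50000 nM in this assay, at which 4 of the 4 values shown sit. The compounds shown leave open whether any aryl group at this place on the shared core can bring a value inside the assay's range.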